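The source may report more compounds than this note shows. Statements on the series, on what has been measured and on what is new or still open speak of the compounds shown alone.

Working notes on the series. Compound 1 `CC(C)(C)Cc1c(-c2ccncc2)sc(N)c1C(=O)c1ccc(Cl)cc1`, compound 2 `COc1cccc(-c2sc(N)c(C(=O)c3ccc(Cl)cc3)c2CC(C)(C)C)c1` and compound 3 `COc1ccccc1-c1sc(N)c(C(=O)c2ccc(Cl)cc2)c1CC(C)(C)C` share one core and differ only in the aromatic group on the five-membered ring. In an assay on CHO cells for displacement of a labelled ligand from adenosine receptor A1 (Homo sapiens), read by scintillation counting, tested at 10 uM (a lower number here means less inhibition, a higher number more inhibition at the concentration tested (going by the name of the read-out)), compound 1 gives 1%, compound 2 gives 1% and compound 3 gives 1%. The step of no change at the digits printed from compound 1 to compound 2 (within the scatter), 3-methoxyphenyl in place of pyridin-4-yl, and the step of no change at the digits printed from compound 1 to compound 3 (within the scatter), 2-methoxyphenyl in place of pyridin-4-yl, both stay within the scatter, as does the step of no change at the digits printed from compound 2 to compound 3 (within the scatter), 2-methoxyphenyl in place of 3-methoxyphenyl. Compound 3 therefore stands level with compound 1 and compound 2 in this assay, none of the three separated from another beyond the scatter.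

Compound 4 `CC(C)c1ccc(-c2sc(N)c(C(=O)c3ccc(Cl)cc3)c2CC(C)(C)C)cc1` has not yet been measured in this assay. It differs from compound 3 as follows: 4-isopropylphenyl in place of 2-methoxyphenyl on an aromatic carbon. All three measured steps bear on this change, since each exchanges the aromatic group at the same ring carbon, and none of them moved the read-out beyond the scatter. Among the measured compounds shown here, nothing among the measured compounds suggests that a fourth aromatic group at this position would behave differently. The expected step is a number 1 percentage points higher from compound 3 to compound 4 (within the scatter), none beyond the scatter. In this assay compound 4 is therefore estimated at 2%, expected between -8% and 12%.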

Compound 4, a percentage reported as inhibition, at one concentration (the size of the read-out at that concentration, not a potency): 1%
Estimate against measurement, compound 4: 1 percentage points above, within the range that was stated.
By their numbers in this assay, from the lowest: compounds 1, 2, 3 and 4 (each within the scatter of the next).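

In this assay, 4-isopropylphenyl brings to this aromatic carbon, next to the ring sulfur, a group of carbon only with no hydrogen-bond acceptor, and the swap for 2-methoxyphenyl gives no change at the digits printed from compound 3 to compound 4 (within the scatter). The comparisons with the other two aromatic groups read the same way: 4-isopropylphenyl in place of 3-methoxyphenyl gives no change at the digits printed from compound 2 to compound 4 (within the scatter), and 4-isopropylphenyl in place of pyridin-4-yl gives no change at the digits printed from compound 1 to compound 4 (within the scatter), so across these four compounds neither the methoxy oxygen, nor the pyridine ring nitrogen, nor an isopropyl group on the phenyl ring separates one compound from another in this read-out. No evidence accompanying these results accounts for the flat read-out.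

The compounds shown leave open whether an aromatic group bearing an amine or a carboxylic acid, or a longer chain in place of the aromatic group at this carbon, would move the read-out beyond the scatter. They also leave open what happens when the neopentyl, amino or (4-chlorophenyl)carbonyl group changes, for example with methyl in place of neopentyl, since all four compounds carry these three groups unchanged.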